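This account rests on a few compounds, and the source may have more. Where it says the series, first, only, none or still open, it means among the compounds named here.

Compound 2 `Fc1cc(Cl)ccc1-n1c(=S)n2n(c1=S)CCCC2` sits at the low end of the three numbers in a functional assay on the whole organism with Scenedesmus acutus as the target, with a stated time of 20 h; a higher number here means a weaker inhibitor, a lower number a stronger inhibitor: compound 2 gives 27.5 nM, compound 1 `S=c1n(-c2ccc(Cl)cc2)c(=S)n2n1CCCC2` gives 50.1 nM, and compound 3 `S=c1s/c(=N\c2ccccc2)n2n1CCCC2` gives 4370 nM, the last beyond the scatter from compound 2, the first within it. Compound 4 `CC(C)Oc1cc(-n2c(=S)n3n(c2=S)CCCC3)c(F)cc1Cl` differs from compound 2 by isopropoxy in place of hydrogen on an aromatic carbon. Going by the values given here, the only measured step on the aryl ring, a 1.8-fold lower number from compound 1 to compound 2 (0.26 log units; within the scatter), lies within the scatter, and no measured step exchanges hydrogen for isopropoxy anywhere. The change is therefore without precedent in these data, and the expected step of a 1.5-fold higher number from compound 2 to compound 4 (0.16 log units; within the scatter) for compound 4 is small, with wide uncertainty around it. Compound 4 is estimated at 40 nM, expected to fall between 10 nM and 160 nM.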

Compound 4, half-maximal inhibitory concentration: 67.6 nM
The estimate for compound 4 lay 1.7-fold (0.23 log units) below the measured number; measured number inside the range.
By their numbers in this assay, from the lowest: compounds 2, 1 and 4 (each within the scatter of the next, the first and the last beyond it); then compound 3.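

In this assay, isopropoxy on the aromatic carbon ortho to the chloro group and para to the fluoro group gives a modest change: a 2.5-fold higher number from compound 2 to compound 4 (0.39 log units; beyond the scatter). Going by these compounds alone, this is the first step on the aromatic ring beyond the scatter, and it shows that this position tolerates a group of 4 heavy atoms with only a modest rise in the number. No measurement at hand bears on the reason for the rise.

With one group at this position, no trend can be drawn. As far as these compounds go, whether a methoxy group, an amine or a carboxylic acid there would give a similar number remains open.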